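The source may report more compounds than this note shows. Statements on the series, on what has been measured and on what is new or still open speak of the compounds shown alone.

Measured compounds:
Compound 1, `O=C(C1CCC(F)(F)CC1)N1CC(c2nc(-c3cccc(F)c3)no2)C1`, in an assay on HEK293 cells for negative allosteric modulation of metabotropic glutamate receptor 5 (Homo sapiens), read by FLIPR (on this read-out higher numbers stand for weaker inhibition and lower numbers for stronger inhibition), compound 1 gives only a limit of the assay, > 10000 nM.
Compound 2, `O=C(N1CCC(F)CC1)N1CC(c2nc(-c3cccc(Cl)c3)no2)C1`, in this assay compound 2 gives likewise only a limit, > 10000 nM.

Compound 2 therefore stands at the limit of > 10000 nM in this assay, at which 2 of the 2 values shown sit, with no number of its own to rank it. Among the measured compounds shown here, compound 1 sits at the same limit, so the two cannot be told apart, and no step between measured compounds is available.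

Compound 3, `CC1CN(C(=O)N2CC(c3nc(-c4cccc(Cl)c4)no3)C2)CC(C)O1`, remains to be measured in this assay. Its change from compound 2 is 2,6-dimethylmorpholin-4-yl in place of 4-fluoropiperidin-1-yl on a carbonyl carbon. The measured pair offers no guidance on whether such an exchange moves inhibition; what the data show is that two amide partners at this carbonyl, one of them a fluorinated piperidine, both gave no number at all. The expected step that the limit leaves unreadable from compound 2 to compound 3 is accordingly none beyond the scatter, with the most likely outcome again a limit rather than a value. Compound 3 is estimated at 15000 nM in this assay, within a range from 3000 nM to 60000 nM.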

Compound 3, half-maximal inhibitory concentration: 990 nM
Beside the measured number, compound 3's estimate is 15-fold (1.18 log units) above it, outside the stated range (below it).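

In this assay, putting 2,6-dimethylmorpholin-4-yl in place of 4-fluoropiperidin-1-yl on a carbonyl carbon gives an at least 10-fold lower number from compound 2 to compound 3 (1.00 log units; beyond the scatter), and this is the first readable number among the compounds shown. The position is therefore not closed to inhibition: with the rest of the molecule unchanged, the exchange of this one group is enough to move a compound from a limit of the assay to a measured value. The step is a bound and not a measured size, since compound 2 stands only at a limit: the limit of > 10000 nM in this assay, at which 2 of the 3 values shown sit.

The ring oxygen and the two methyl groups enter together, so the compounds shown do not tell which of them goes with the stronger inhibition; morpholin-4-yl without the methyl groups and 2,6-dimethylpiperidin-1-yl without the ring oxygen would pull the two apart. Also open, going by these compounds, is whether the gain from this exchange carries over to other substituents on the rest of the molecule, or how far it can be extended with larger groups such as 2,6-diethylmorpholin-4-yl.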